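A Fluoro Step on Compound 2

This account rests on a few compounds, and the source may have more. Where it says the series, first, only, none or still open, it means among the compounds named here.

Of the compounds shown here, two have been measured so far. For the measured compounds named here, in a functional assay on HEp-2 cells (Homo sapiens) for cytotoxicity (a higher number here means a weaker inhibitor, a lower number a stronger inhibitor), compound 2 (`Nc1ncnc2c1nnn2[C@H]1C[C@H](O)[C@@H](CO)O1`) gives 10000 nM as the only true number on the scale. Compound 1 (`Nc1nc(F)nc2nn(C3O[C@H](CO)[C@@H](O)[C@H]3O)nc12`) returns > 75000 nM in this assay and this is a limit, not a number. Compound 3 (`Nc1nc(F)nc2c1nnn2[C@H]1C[C@H](O)[C@@H](CO)O1`) awaits measurement. It departs from compound 2 by a single change, (fluoro in place of hydrogen on an aromatic carbon), with fluoro in place of hydrogen on an aromatic carbon, between two ring nitrogen atoms. Going by the values given here, no measured pair isolates this change, so only a cautious expectation is possible in this assay. Compound 1 also carries fluoro, and its limit of > 75000 nM tilts the expectation towards a modestly weaker inhibitor. The expected change is a 2.0-fold higher number from compound 2 to compound 3 (0.30 log units; within the scatter) as an estimate. For compound 3 the estimated value is 20000 nM and it is expected to fall between 4000 nM and 75000 nM in most repeats.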

Compound 3, half-maximal inhibitory concentration: 70000 nM
Compound 3: the middle estimate sits 3.5-fold (0.54 log units) below what was measured; the measured number falls inside the stated range.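

For the compounds shown here, this is the first pair to isolate the change: in this assay, fluoro in place of hydrogen on an aromatic carbon, between two ring nitrogen atoms, gives a 7.0-fold higher number from compound 2 to compound 3 (0.85 log units; beyond the scatter). A single fluorine atom at this place is thus enough to move the read-out beyond the usual scatter, towards a weaker inhibitor. Going by these compounds alone, compound 1 also carries fluoro, but it differs from compound 3 in more than one place and offers no step, only a limit: the limit of > 75000 nM in this assay, at which 1 of the 3 values shown sits.

The compounds shown leave open whether this shift belongs to fluoro itself or would follow other replacements of hydrogen on the same carbon, such as chloro, a methyl group or an amine. They also leave open whether fluoro would give a similar step on the core of compound 1.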